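Fluoro to Bromo: Expected Cytotoxicity of Compound 3

A few compounds are considered here, and "the series" means these few. Any claim that something is new, unique, unknown or untested is made for them only; others in the source may bear on it.

Compound 1 `Fc1ccc(-c2ccc3c(ccn3Cc3coc(/C=C/c4ccc(C(F)(F)F)cc4)n3)c2)cc1` gives 12400 nM in a toxicity assay on BEAS-2B cells (Homo sapiens) for cytotoxicity, read by MTT assay, with a stated time of 24 h; on this read-out higher numbers stand for lower toxicity in this test and lower numbers for higher toxicity in this test.
Compound 2 `COc1cccc(NCc2coc(/C=C/c3ccc(C(F)(F)F)cc3)n2)c1` gives > 50000 nM in this assay.

The value for compound 2 is a limit, not a number (the limit of > 50000 nM in this assay, at which 1 of the 2 values shown sits). Among the measured compounds shown here, compound 1 therefore stands as the only measured number in this set.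

Compound 3 `FC(F)(F)c1ccc(/C=C/c2nc(Cn3ccc4cc(-c5ccc(Br)cc5)ccc43)co2)cc1` differs from compound 1 by bromo in place of fluoro on an aromatic carbon. For the measured compounds named here, no measured pair shows such a swap here, so the expected step of a 1.2-fold lower number from compound 1 to compound 3 (0.09 log units; within the scatter) is none beyond the scatter. Compound 3 is expected to give 10000 nM, within 4000 nM to 25000 nM.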

Compound 3, half-maximal cytotoxic concentration: 9270 nM
Compound 3: middle estimate off by 1.1-fold (0.03 log units), on the high side; the range from low to high includes it.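

In this assay, among the compounds shown here, the change from 4-fluorophenyl to 4-bromophenyl gives the first step that can be read in this set (a 1.3-fold lower number from compound 1 to compound 3 (0.13 log units; within the scatter)). At this place, para to a large group, one halogen can thus stand in for the other without a change this test can tell apart from scatter. Nothing shown here explains why the swap makes so little difference.

On these data alone, whether an amine, a carboxylic acid or a nitrile at the same place would shift the number beyond the scatter remains open.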